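The source may hold more compounds than are shown below. What is called first, only, known or untested is meant among the compounds shown, and "the series" means these compounds.

Measured so far:
compound 1 `Cc1ccc(OC[C@@H]2CCCN2C)cn1`, 1.26 nM;
compound 2 `CN1CCC[C@H]1COc1ccc(Cl)nc1`, 0.64 nM.

In an assay on membranes from brain for displacement of a labelled ligand from Neuronal acetylcholine receptor; alpha4/beta2 (Rattus norvegicus) (a higher number here means a weaker inhibitor, a lower number a stronger inhibitor), compound 2 gives 0.64 nM, the lower of the two numbers, though the step of a 2.0-fold lower number from compound 1 to compound 2 (0.29 log units; within the scatter) leaves compound 1 within the scatter of it. Compound 3 `CN1CCC[C@H]1COc1ccc(Br)nc1` differs from compound 2 by bromo in place of chloro on an aromatic carbon. Going by the values given here, the only measured step bearing on this position is the exchange of methyl for chloro, a 2.0-fold lower number from compound 1 to compound 2 (0.29 log units; within the scatter), which did not move this assay beyond the scatter; a further halogen swap at the same carbon is therefore expected to give no step beyond the scatter. Compound 3 is estimated at 0.6 nM, range 0.25 nM to 1.5 nM, an expected step of a 1.1-fold lower number from compound 2 to compound 3 (0.03 log units; within the scatter).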

Compound 3, inhibition constant: 1.91 nM
The estimate for compound 3 lay 3.2-fold (0.50 log units) below the measured number; the whole stated range lies below it.
By their numbers in this assay, from the lowest: compounds 2, 1 and 3 (each within the scatter of the next, the first and the last beyond it).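

In this assay, going by these compounds alone, this position proves sensitive to the choice of halogen: a 3.0-fold higher number from compound 2 to compound 3 (0.47 log units; beyond the scatter) is the first single exchange to pass the scatter, though only modestly. Bromo and methyl remain indistinguishable here, with a 1.5-fold higher number from compound 1 to compound 3 (0.18 log units; within the scatter) in this assay. No measurement at hand accounts for the difference between chloro and bromo.

Still open, as far as these compounds go, is how fluoro, an amine or a methoxy group on this aromatic carbon would compare with chloro. From the compounds shown here alone, whether the step from chloro to bromo carries over to other cores also remains unknown.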